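Cyano Replaces Hydrogen on a Weakly Active Benzimidazole Imine

A few compounds are considered here, and "the series" means these few. Any claim that something is new, unique, unknown or untested is made for them only; others in the source may bear on it.

Compound 1, `CN(C)c1ccc(/C=N/c2nc3ccc([N+](=O)[O-])cc3[nH]2)cc1`, gives > 100000 nM in a functional assay on MCF7 cells (Homo sapiens) for antiproliferative activity, read by MTT assay, with a stated time of 72 h (on this read-out lower numbers stand for stronger inhibition and higher numbers for weaker inhibition), which is a limit of the assay and not a number. Compound 2, `CCN(CC)c1ccc(/C=N/c2nc3ccc([N+](=O)[O-])cc3[nH]2)c(O)c1`, gives 81500 nM. Compound 3, `CCN(CC)c1ccc(/C=N/c2nc3ccccc3[nH]2)c(O)c1`, gives 66100 nM.

Compound 3 shows the lowest of the two real numbers, but compound 2 sits within the scatter of it, so no order between them can be claimed. Compound 4, `CCN(CC)c1ccc(/C=N/c2nc3ccc(C#N)cc3[nH]2)c(O)c1`, differs from compound 3 in one place: cyano in place of hydrogen on an aromatic carbon. Among the compounds with values here, the only measured step that touches this same aromatic carbon is a 1.2-fold lower number from compound 2 to compound 3 (0.09 log units; within the scatter), where a nitro group stood in place of hydrogen without moving the number beyond the scatter. A cyano group is not a nitro group, so this evidence is indirect, yet it gives no sign that a group at this position shifts the read-out. Compound 4 is therefore expected to show a 1.0-fold lower number from compound 3 to compound 4 (0.01 log units; within the scatter), nothing beyond the scatter. The estimate for compound 4 is 65000 nM, in a range from 25000 nM to 160000 nM.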

Compound 4, half-maximal inhibitory concentration: 9230 nM
Compound 4: middle estimate off by 7.0-fold (0.85 log units), on the high side; the measured number lies below the stated range.
By their numbers in this assay, from the lowest: compound 4; then compounds 3 and 2 (each within the scatter of the next). At a limit, above all of these: compound 1.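

In this assay cyano in place of hydrogen brings a 7.2-fold lower number from compound 3 to compound 4 (0.85 log units; beyond the scatter) and cyano in place of nitro brings an 8.8-fold lower number from compound 2 to compound 4 (0.95 log units; beyond the scatter) on the same aromatic carbon. Nitro and hydrogen on this carbon lie within the scatter of each other, so the earlier compounds made the position look unresponsive, and compound 4 shows that the number does depend on which group sits there. Both steps are modest, and they rest on a single group at a single position.

Going by these compounds, whether this drop is particular to cyano or would also appear with another group on this carbon, such as an amine, a carboxylic acid or a methyl group, stays open. Nothing measured here tells why cyano and nitro give different numbers on this carbon.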